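Ring Size at the Basic Amine in a Weak Series

A few compounds are considered here, and "the series" means these few. Any claim that something is new, unique, unknown or untested is made for them only; others in the source may bear on it.

Of the compounds shown here, three have been measured in a functional assay on L02 cells (Homo sapiens) for inhibition; a higher number here means a weaker inhibitor, a lower number a stronger inhibitor. Compound 1 `O=C(CC(CC(=O)NC1Cc2ccccc2C1)c1ccc(Cl)cc1)NCCN1CCCCC1` and compound 2 `O=C(CC(CC(=O)NC1Cc2ccccc2C1)c1ccc(Cl)cc1)NCCN1CCCC1` share one core and differ only at the end of the chain. In this assay compound 1 gives 70400 nM. In this assay compound 2 gives 89400 nM. The change between them is piperidin-1-yl in place of pyrrolidin-1-yl on a saturated chain carbon, two bonds along the chain from an amide-type nitrogen, and it made a 1.3-fold lower number from compound 2 to compound 1 (0.10 log units; within the scatter). Compound 3 `CCN(C(=O)CC(CC(=O)NCCN1CCCC1)c1ccccc1)C1Cc2ccccc2C1` is built on another core; the difference between the two cores is not broken down here. In this assay compound 3 gives only a limit, > 100000 nM. Compound 4 `CCN(C(=O)CC(CC(=O)NCCN1CCCCC1)c1ccccc1)C1Cc2ccccc2C1` carries the same kind of change on the core of compound 3, namely (piperidin-1-yl in place of pyrrolidin-1-yl on a saturated chain carbon, two bonds along the chain from an amide-type nitrogen). The step is expected to be a step that the limit leaves unreadable from compound 3 to compound 4, since the earlier step in the same place, a 1.3-fold lower number from compound 2 to compound 1 (0.10 log units; within the scatter), was small. Because compound 3 stands at the limit of > 100000 nM in this assay, at which 1 of the 3 values shown sits, compound 4 is also expected to be reported as a limit rather than a number. Compound 4 is estimated at 150000 nM, between 70000 nM and 320000 nM.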

Compound 4, half-maximal inhibitory concentration: > 100000 nM
Compound 4: no number, only a limit; the forecaster's own chance of this, stated with the estimate: 80%; the middle value is on the limit's open side.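

In this assay compound 4 gives only a limit, > 100000 nM. Going by these compounds alone, compound 3 also gives only a limit, so no step between compound 3 and compound 4 can be read. The compounds shown leave open whether piperidin-1-yl in place of pyrrolidin-1-yl does on the core of compound 3 what it does on the core of compound 1.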